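This account rests on a few compounds, and the source may have more. Where it says the series, first, only, none or still open, it means among the compounds named here.

Values below come from an ADME assay on Huh-7 cells (Homo sapiens) for cytotoxicity; on this read-out lower numbers stand for higher toxicity in this test and higher numbers for lower toxicity in this test.

Measured compounds:
compound 1, `Cc1ccccc1-c1nn(-c2ccc(Cl)cc2)cc1CNCCN1CCN(C)CC1`: 17000 nM
compound 2, `CN1CCN(CCCNCc2cn(-c3ccc(C(F)(F)F)cc3)nc2-c2ccc(C(F)(F)F)cc2)CC1`: 2000 nM
compound 3, `Cc1ccccc1-c1nn(-c2ccc(C(F)(F)F)cc2)cc1CNCCN1CCN(C)CC1`: 11000 nM

Compound 2 gives the lowest number of the three in this assay, with compound 3 nearest and compound 1 furthest, both gaps beyond the scatter. Compound 3 and compound 1 share a core and differ in one place only: chloro in place of trifluoromethyl on an aromatic carbon. This change gives a 1.5-fold higher number from compound 3 to compound 1 (0.19 log units; within the scatter), so the two values are read as equal. The core of compound 2 differs from the core of compound 3 in more than one place; that difference is not broken down here.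

Compound 4, `CN1CCN(CCCNCc2cn(-c3ccc(C(F)(F)F)cc3)nc2-c2ccc(Cl)cc2)CC1`, has not yet been measured in this assay. It is derived from compound 2 by chloro in place of trifluoromethyl on an aromatic carbon. The place of the change reads word for word as it does between compound 3 and compound 1, so this is the same change made on a different core. From compound 2 to compound 4 a step of about a 1.4-fold higher number from compound 2 to compound 4 (0.13 log units; within the scatter) is expected, because a 1.5-fold higher number from compound 3 to compound 1 (0.19 log units; within the scatter) was small and within the scatter; the expectation rests on that single pair and on the value of compound 2, 2000 nM. Compound 4 is therefore estimated at 2700 nM, with a range of 1200 nM to 6500 nM.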

Compound 4, half-maximal cytotoxic concentration: 2500 nM
For compound 4 the middle estimate is 1.1-fold (0.03 log units) above the measured one, within the range that was stated.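

In this assay, the change from 4-(trifluoromethyl)phenyl to 4-chlorophenyl gives a 1.3-fold higher number from compound 2 to compound 4 (0.10 log units; within the scatter), so on the core of compound 2 it leaves no difference that can be read. The change behaves alike on both cores, and in these two pairs it carries from one core to the other with no detectable shift on this read-out: the same change on two cores in this assay, a 1.5-fold higher number (0.19 log units; within the scatter) from compound 3 to compound 1 and a 1.3-fold higher number (0.10 log units; within the scatter) from compound 2 to compound 4, 1.2-fold (0.09 log units) apart, within the scatter of two such steps. This rests on two pairs only, both within the scatter, so it does not show that the change would stay silent on a further core or in another test, and it gives neither a size for the step that can be told from zero nor a reason for the agreement.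

The compounds shown leave open how other groups on that aromatic carbon, such as fluoro, methoxy or nitrile, would read, and what chloro would do in place of the trifluoromethyl that remains in compound 4. Also open, as far as these compounds go, is which part of the difference between the core of compound 2 and the core of compound 3 matters on this read-out, a question that pairs differing only in the chain carrying the methylpiperazine-type amine, or only in the methyl-bearing aryl group, could address.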